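Working notes: from compound 3 to compound 4

This account rests on a few compounds, and the source may have more. Where it says the series, first, only, none or still open, it means among the compounds named here.

Values in a functional assay on cells (leukaemia cell line, Homo sapiens) for inhibition, read by sulforhodamine B assay, with a stated time of 48 h; on this read-out higher numbers stand for weaker inhibition of growth and lower numbers for stronger inhibition of growth:
- Compound 1 `Cc1cc(NS(=O)(=O)c2ccc(-c3cnc(C4CC4)o3)cc2)ccc1Cl`: 216 nM
- Compound 2 `O=S(=O)(Nc1ccc(F)cc1F)c1ccc(-c2cnc(C3CC3)o2)cc1`: 356 nM
- Compound 3 `O=S(=O)(Nc1cc(Cl)ccc1Cl)c1ccc(-c2cnc(C3CC3)o2)cc1`: 1020 nM
- Compound 4 `Cc1cc(Cl)ccc1NS(=O)(=O)c1ccc(-c2cnc(C3CC3)o2)cc1`: not yet measured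

Of the three measured compounds, compound 3 has the highest number at 1020 nM, which makes it the weakest growth inhibitor so far. The next change is 4-chloro-2-methylphenyl in place of 2,5-dichlorophenyl on a sulfonamide nitrogen, in words 4-chloro-2-methylphenyl in place of 2,5-dichlorophenyl on a sulfonamide nitrogen.

Going by the values given here, no measured compound carries this exact group, so the available steps bear on it only indirectly. Both measured steps into compound 3 are modest: a 2.9-fold higher number from compound 2 to compound 3 (0.46 log units; beyond the scatter) and a 4.7-fold higher number from compound 1 to compound 3 (0.67 log units; beyond the scatter). Between the other two there is only a 1.6-fold higher number from compound 1 to compound 2 (0.22 log units; within the scatter), so compounds 1 and 2 form one lower level, and compound 3 lies apart from it. Compound 1 is the closest guide, as its phenyl also bears a chloro and a methyl group, although the arrangement differs from that in compound 4.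

A modest move to a lower number is therefore expected, probably not the full distance to compound 1. The expected step in this assay is a 2.4-fold lower number from compound 3 to compound 4 (0.39 log units; beyond the scatter). For compound 4 the estimated value is 420 nM, with an expected range from 170 nM to 1050 nM.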

Compound 4, concentration for 50% growth inhibition: 277 nM
Compound 4: middle estimate off by 1.5-fold (0.18 log units), on the high side, and the stated range covers the measured number.
By their numbers in this assay, from the lowest: compounds 1, 4 and 2 (each within the scatter of the next); then compound 3.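

In this assay, 4-chloro-2-methylphenyl in place of 2,5-dichlorophenyl on a sulfonamide nitrogen gives a 3.7-fold lower number from compound 3 to compound 4 (0.57 log units; beyond the scatter) and shows that a single group change at this position can return the series from the level of compound 3 to the lower level. The chloro and methyl pattern on this phenyl can also vary without a measurable change, as 4-chloro-2-methylphenyl in place of 4-chloro-3-methylphenyl gives a 1.3-fold higher number from compound 1 to compound 4 (0.11 log units; within the scatter) and 4-chloro-2-methylphenyl in place of 2,4-difluorophenyl gives a 1.3-fold lower number from compound 2 to compound 4 (0.11 log units; within the scatter), which leaves compound 3 alone as the weakest of the four. No measured evidence is available to explain why 2,5-dichlorophenyl stands apart.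

The compounds shown leave open how this position responds to an unsubstituted phenyl or to a phenyl bearing methoxy, an amine or a carboxylic acid. From the compounds shown here alone, whether the higher number of compound 3 belongs to 2,5-dichlorophenyl alone or to dichlorophenyl groups more widely also remains open.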